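Swapping the Benzoyl Halogens of Compound 2

The source may report more compounds than this note shows. Statements on the series, on what has been measured and on what is new or still open speak of the compounds shown alone.

Measured so far in an in vitro ADME assay on microsomes from liver (Rattus norvegicus) for metabolic stability; on this read-out lower numbers stand for slow clearance and higher numbers for fast clearance:
Compound 1 `CC(C)NC(=O)[C@H]1CC[C@@H](n2/c(=N/C(=O)c3ccc(F)cc3)[nH]c3ccc(CN4CC(C(C)(C)O)C4)cc32)CC1`: < 14 mL.min-1.g-1 (a limit of the assay, not a number)
Compound 2 `CC(C)NC(=O)[C@H]1CC[C@@H](n2/c(=N/C(=O)c3cc(F)cc(Cl)c3)[nH]c3ccc(CN4CCC(C(C)(C)O)CC4)cc32)CC1`: 43 mL.min-1.g-1

Within the data shown here, only one true number is available so far. In this assay compound 2 gives 43 mL.min-1.g-1. Compound 1 is reported only as a limit, < 14 mL.min-1.g-1. Among the measured compounds shown here, no pair of measured compounds isolates a single structural change, so the data offer no direct guide to the size of the next step.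

Compound 3 `CC(C)NC(=O)[C@H]1CC[C@@H](n2/c(=N/C(=O)c3ccc(F)c(F)c3)[nH]c3ccc(CN4CCC(C(C)(C)O)CC4)cc32)CC1` differs from compound 2 in one place: 3,4-difluorophenyl stands in place of 3-chloro-5-fluorophenyl on a carbonyl carbon (3,4-difluorophenyl in place of 3-chloro-5-fluorophenyl on a carbonyl carbon). The group that enters has the same number of heavy atoms as the one that leaves, with a second fluorine where the chlorine was counted.

With so little to go on, only a small fall in this assay is expected, a 1.4-fold lower number from compound 2 to compound 3 (0.16 log units; within the scatter), and this would stay within the usual scatter of repeated measurements. The estimate in this assay for compound 3 is 30 mL.min-1.g-1, with an expected range from 15 mL.min-1.g-1 to 60 mL.min-1.g-1.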

Compound 3, intrinsic clearance in microsomes: 19 mL.min-1.g-1
For compound 3 the middle estimate is 1.6-fold (0.20 log units) above the measured one; measured number inside the range.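

Among these compounds, this is the first pair in which a single change can be read on its own. With everything else held fixed, 3,4-difluorophenyl in place of 3-chloro-5-fluorophenyl on a carbonyl carbon gives a 2.3-fold lower number from compound 2 to compound 3 (0.35 log units; beyond the scatter) in this assay, so the direction is towards slower clearance and the modest step lies beyond the scatter. The position therefore responds to a change in the halogens alone, even though both groups have the same count of heavy atoms and the same single carbon-only aromatic ring, and neither carries a hydrogen-bond donor or acceptor.

The swap removes the chlorine and also changes where the halogens sit on the ring, so one step cannot tell which of the two matters; a 3,5-difluorophenyl group on the same carbonyl carbon would separate them, while a plain phenyl group would show what the halogens add at all. Further falls may also be harder to size, as compound 1 is reported only as a limit of the assay, not a number: the limit of < 14 mL.min-1.g-1 in this assay, at which 1 of the 3 values shown sits.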